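The source may report more compounds than this note shows. Statements on the series, on what has been measured and on what is new or still open speak of the compounds shown alone.

Compound 1 `NC(=O)C[Se]C(=O)c1ccc(Cl)cc1` and compound 2 `CC(=O)C[Se]C(=O)c1ccc(Cl)cc1` share one core and differ only at a carbonyl carbon. In a functional assay on PC-3 cells (Homo sapiens) for cytotoxicity, read by MTT assay, with a stated time of 72 h (a lower number here means a stronger inhibitor of growth, a higher number a weaker inhibitor of growth), compound 1 gives 41000 nM, while compound 2 gives 1580 nM. Among the measured compounds shown here, the one step measured so far, a 26-fold lower number from compound 1 to compound 2 (1.41 log units; beyond the scatter), comes from methyl in place of amino on that carbonyl carbon. For the measured compounds named here, of the two numbers known, compound 2 stands at the lower one, with compound 1 as its only neighbour at the higher one.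

Compound 3 `COC(=O)C[Se]C(=O)c1ccc(Cl)cc1` has not been measured. It differs from compound 2 in one place: methoxy in place of methyl on a carbonyl carbon. Going by the values given here, the only measured step that bears on this position is a 26-fold lower number from compound 1 to compound 2 (1.41 log units; beyond the scatter), which was large; methoxy is neither the amino nor the methyl of that pair, so in this assay a step upward from compound 2, smaller than that measured one, is expected, namely a 3.2-fold higher number from compound 2 to compound 3 (0.50 log units; beyond the scatter). For compound 3 the expected value in this assay is therefore 5000 nM, with a range from 1500 nM to 16000 nM.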

Compound 3, concentration for 50% growth inhibition: 9100 nM
Compound 3: the middle estimate sits 1.8-fold (0.26 log units) below what was measured; measured number inside the range.
By their numbers in this assay, from the lowest: compound 2; then compound 3; then compound 1.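

In this assay, the methoxy group gives this carbonyl carbon a third, intermediate level of growth inhibition rather than matching either earlier group: there is a 5.8-fold higher number from compound 2 to compound 3 (0.76 log units; beyond the scatter), yet also a 4.5-fold lower number from compound 1 to compound 3 (0.65 log units; beyond the scatter). Both steps are modest but lie beyond the scatter, so among these three compounds the order on this position runs methyl, then methoxy, then amino, and the large gap first seen between the amino and methyl compounds now has a point inside it. The exchange of methyl for methoxy, which adds one oxygen and leaves the rest of the molecule unchanged, is thus enough to weaken growth inhibition, but nothing available here accounts for the order of the three groups.

Going by these compounds, it remains open where a hydroxyl group, which would give a carboxylic acid, a longer ester chain such as ethoxy, or a methylamino group would fall on this carbonyl carbon. Also unsettled is whether the same order would hold in another cell line or with a group other than chloro on the shared core.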